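Azetidin-1-yl in place of an arylamino group on the shared core

The source may report more compounds than this note shows. Statements on the series, on what has been measured and on what is new or still open speak of the compounds shown alone.

Measured so far:
compound 1 `Cc1ccc(NC2=CC(=O)c3c(nc4n3[C@H]3OC[C@@H](O)[C@H]3OC4)C2=O)cc1C` gives 1050 nM
compound 2 `COc1ccc(NC2=CC(=O)c3c(nc4n3[C@H]3OC[C@@H](O)[C@H]3OC4)C2=O)cc1` gives 2150 nM

Both values come from a functional assay on MGC-803 cells (Homo sapiens) for inhibition, read by sulforhodamine B assay; on this read-out higher numbers stand for weaker inhibition and lower numbers for stronger inhibition. Of the two, compound 2 holds the higher number (2150 nM), which makes it the weaker inhibitor of the pair. The next compound, compound 3 `O=C1C(N2CCC2)=CC(=O)c2c1nc1n2[C@H]2OC[C@@H](O)[C@H]2OC1`, departs from compound 2 by azetidin-1-yl in place of (4-methoxyphenyl)amino on a double-bonded ring carbon, with azetidin-1-yl in place of (4-methoxyphenyl)amino on a double-bonded ring carbon.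

Within the data shown here, only one measured step bears on this change: a 2.0-fold higher number from compound 1 to compound 2 (0.31 log units; beyond the scatter), which is modest and beyond the scatter. That step exchanges one substituted phenyl group for another on an amine nitrogen. Here the six-membered aromatic ring leaves and a four-membered non-aromatic ring enters, so no measured step covers a change of this kind. The size and direction in this assay are therefore poorly bounded. A modest rise in the number is expected, not a large move, and the estimated change is a 1.5-fold higher number from compound 2 to compound 3 (0.19 log units; within the scatter) with a wide margin. For compound 3 the expected value is 3300 nM within an estimated range (800 nM to 13000 nM).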

Compound 3, half-maximal inhibitory concentration: > 16000 nM
Compound 3 was reported as a limit; the forecaster's own chance of this, stated with the estimate: 10%; at least 4.8-fold (0.68 log units) between middle value and limit.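

In this assay compound 3 gives > 16000 nM, a limit of the assay and not a number. On this double-bonded ring carbon, exchanging one substituted phenyl group for another gave only a 2.0-fold higher number from compound 1 to compound 2 (0.31 log units; beyond the scatter), whereas azetidin-1-yl in place of the arylamino group gives an at least 7.4-fold higher number from compound 2 to compound 3 (0.87 log units; beyond the scatter) and an at least 15-fold higher number from compound 1 to compound 3 (1.18 log units; beyond the scatter), so within these three compounds the change from an arylamino group to azetidin-1-yl is the larger move, and neither arylamino compound goes against this. Both new steps fix only a minimum size, and the true size of the loss on moving to azetidin-1-yl stays unknown: the limit of > 16000 nM in this assay, at which 1 of the 3 values shown sits.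

The change removes the six-membered aromatic ring and the hydrogen-bond donor together and also reduces the heavy-atom count, so the compounds shown cannot assign the loss to any one of these differences. Cyclobutylamino would keep the amine hydrogen without the aromatic ring, piperidin-1-yl would give a larger ring without that hydrogen, and benzylamino would keep both with the aromatic ring set one carbon further out, so these groups would begin to separate the three differences.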